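The compounds below may be only part of what the source reports. "The series", "measured", "known", "first", "only" and "open" are said of these compounds alone.

Going by the values given here, in a functional assay on Jurkat cells (Homo sapiens) for cytotoxicity, with a stated time of 48 h (a lower number here means a stronger inhibitor, a higher number a weaker inhibitor), only two compounds have numbers so far. Compound 1 (`CCCc1ccc2c(c1)C(CC(=O)OCC)C(C(=O)OCC)=C(N)O2`) gives 57300 nM and compound 2 (`CC(=O)N(C(C)=O)C1=CC(C)c2cc(-c3ccccc3)ccc2O1`) gives 70600 nM in this test. These two values lie within the usual scatter of each other, so compound 1 stands level with compound 2 and neither can be ranked ahead of the other.

Compound 3 (`CCOC(=O)CC1C(C(=O)OCC)=C(N)Oc2ccc(-c3cccc4ccccc34)cc21`) keeps the core of compound 1 and differs in one place. It carries naphthalen-1-yl in place of propyl on an aromatic carbon. Among the compounds with values here, no pair of measured compounds shows a change of this kind, so the data give no direct guide and any expectation remains loose. Even so, exchanging a small chain for two aromatic rings is a large change, and some shift in this assay seems more likely than none. The expected direction is toward a lower number, meaning a stronger inhibitor, and the expected size is moderate: the estimated change is a 2.9-fold lower number from compound 1 to compound 3 (0.46 log units; beyond the scatter) in this reading. For compound 3 the estimated value is 20000 nM with an expected range from 6000 nM to 60000 nM in the same test.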

Compound 3, half-maximal inhibitory concentration: 5830 nM
For compound 3 the middle estimate is 3.4-fold (0.54 log units) above the measured one, outside the stated range (below it).
By their numbers in this assay, from the lowest: compound 3; then compounds 1 and 2 (each within the scatter of the next).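

In this assay, going by these compounds alone, this aromatic carbon proves sensitive to what it carries: exchanging propyl for naphthalen-1-yl, with the rest of the core of compound 1 unchanged, gives a 9.8-fold lower number from compound 1 to compound 3 (0.99 log units; beyond the scatter), a step beyond the scatter and the first single-place comparison in this set. The exchange replaces a chain with no ring by two six-membered aromatic rings of carbon only, while the count of hydrogen-bond donors and acceptors in the group stays the same, so a lower number here does not require either kind of group to be added at this position. Nothing measured here explains why the number falls.

On these data alone, whether the lower number follows the added carbon atoms or the aromatic rings stays open, as the two change together in this single step. A longer chain such as hexyl would test size without a ring, naphthalen-2-yl would test the way the two rings are attached, and an amine on the same carbon would test a group of a different kind.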